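Chromone ethers: amine at chain end, antiproliferative read-out

A few compounds are considered here, and "the series" means these few. Any claim that something is new, unique, unknown or untested is made for them only; others in the source may bear on it.

Measured so far:
compound 1, `O=c1cc(-c2ccccc2)oc2cc(O)c(OCCCCN3CCCCC3)c(O)c12`, 52700 nM
compound 2, `CN1CCN(CCCCOc2c(O)cc3oc(-c4ccccc4)cc(=O)c3c2O)CC1`, 82900 nM

Both were run in a functional assay on BCG823 cells (Homo sapiens) for antiproliferative activity, read by MTT assay, with a stated time of 48 h; on this read-out lower numbers stand for stronger inhibition and higher numbers for weaker inhibition. Compound 2 has the highest of the two numbers; its nearest neighbour is compound 1, and the step of a 1.6-fold higher number from compound 1 to compound 2 (0.20 log units; within the scatter) lies within the scatter, so the two compounds cannot be ordered.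

Compound 3 is `O=c1cc(-c2ccccc2)oc2cc(O)c(OCCCCN3CCCC3)c(O)c12`, not yet measured. The change from compound 2 reads (pyrrolidin-1-yl in place of 4-methylpiperazin-1-yl on a saturated chain carbon, four bonds along the chain from an oxygen on an aromatic ring). Within the data shown here, the only step that bears on it is the one just quoted: exchanging piperidin-1-yl for 4-methylpiperazin-1-yl at the same place moved the number by a 1.6-fold higher number from compound 1 to compound 2 (0.20 log units; within the scatter), which is within the scatter. The present change goes back to a ring with one nitrogen and no methyl, like piperidin-1-yl but one carbon smaller. Among the measured compounds shown here, with only this one step as a guide, the expected step of a 1.5-fold lower number from compound 2 to compound 3 (0.18 log units; within the scatter) is small, tending towards the number of compound 1 rather than away from it, and not beyond the scatter. On that basis the estimate for compound 3 in this assay is 55000 nM, with a range from 25000 nM to 120000 nM.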

Compound 3, half-maximal inhibitory concentration: 86400 nM
Estimate against measurement, compound 3: 1.6-fold (0.20 log units) below; the measured number falls inside the stated range.
By their numbers in this assay, from the lowest: compounds 1, 2 and 3 (each within the scatter of the next).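

The step of a 1.0-fold higher number from compound 2 to compound 3 (0.02 log units; within the scatter) in this assay and the step of a 1.6-fold higher number from compound 1 to compound 3 (0.21 log units; within the scatter) both lie within the scatter, so compound 3 cannot be ordered against either compound 1 or compound 2. The earlier pair covered only six-membered non-aromatic rings, whereas pyrrolidin-1-yl adds a five-membered ring of 5 heavy atoms with 1 hetero atom, and at this place, on a saturated chain carbon four bonds along the chain from an oxygen on an aromatic ring, this difference in ring size also leaves no readable separation among the three compounds. No measurement on hand offers an explanation for this lack of separation.

The compounds shown leave open whether an open-chain amine such as diethylamino, or morpholin-4-yl with its ring oxygen, would also stay within the scatter of these three at the same place. They also leave open whether a shorter or longer chain between the oxygen and the amine, carrying any of these same rings, would give a step beyond the scatter.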